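Pyrimidin-2-yl for pyridin-2-yl on the benzylic aryl

The compounds below may be only part of what the source reports. "The series", "measured", "known", "first", "only" and "open" are said of these compounds alone.

Among the measured compounds shown here, compound 2 `COc1cccc(OC)c1C1CCCC(=O)N1Cc1cccc(-c2ccccn2)c1` gives 9 nM in a functional assay on CHO cells for antagonist activity at Orexin/Hypocretin receptor type 1 (Homo sapiens), read by FLIPR and calcium flux (on this read-out higher numbers stand for weaker inhibition and lower numbers for stronger inhibition), the lowest of the two numbers so far; its nearest neighbour is compound 1 `COc1cccc(OC)c1C1CCCC(=O)N1Cc1cccc(OC(F)(F)F)c1`, which in this assay gives 136 nM, a gap of a 15-fold lower number from compound 1 to compound 2 (1.18 log units; beyond the scatter). Compound 3 `COc1cccc(OC)c1C1CCCC(=O)N1Cc1cccc(-c2ncccn2)c1` carries the change (pyrimidin-2-yl in place of pyridin-2-yl on an aromatic carbon), on an aromatic carbon of a six-membered aromatic ring of carbon only, meta to a large group. For the measured compounds named here, no measured step exchanges one aromatic ring for another at this position; the only step recorded there, a 15-fold lower number from compound 1 to compound 2 (1.18 log units; beyond the scatter), shows that this substituent matters strongly but says nothing about an added ring nitrogen. For compound 3 a step of a 1.3-fold higher number from compound 2 to compound 3 (0.12 log units; within the scatter) in this assay is therefore expected, within the scatter. Compound 3 is estimated at 12 nM, range 4 nM to 40 nM.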

Compound 3, half-maximal inhibitory concentration: 14 nM
Estimate against measurement, compound 3: 1.2-fold (0.07 log units) below; the measured number falls inside the stated range.
By their numbers in this assay, from the lowest: compounds 2 and 3 (each within the scatter of the next); then compound 1.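

In this assay the exchange of pyridin-2-yl for pyrimidin-2-yl on this aromatic carbon gives a 1.6-fold higher number from compound 2 to compound 3 (0.19 log units; within the scatter), so the two rings cannot be told apart on this read-out. The advantage over trifluoromethoxy also holds for pyrimidin-2-yl, with a 9.7-fold lower number from compound 1 to compound 3 (0.99 log units; beyond the scatter), so it does not rest on pyridin-2-yl alone. No measurement shown explains either step.

On these data alone, whether an aromatic ring is needed here remains open. So does how a morpholine, a primary amine or a carboxylic acid would read at this carbon.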